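Furanyl chalcone anilides: nitrooxy chain to aryloxy oxime

A few compounds are considered here, and "the series" means these few. Any claim that something is new, unique, unknown or untested is made for them only; others in the source may bear on it.

Measured so far in a functional assay on the whole organism (strain albino) for inhibition, with Rattus norvegicus as the target, read by paw edema, with stated times of 30 min and 3 h, at a dose of 100 mg/kg by the oral route; on this read-out higher numbers stand for more inhibition at the one dose given (going by the name of the read-out) and lower numbers for less inhibition:
Compound 1 `Nc1ccc(C(=O)/C=C/c2ccco2)cc1` gives 42%.
Compound 2 `O=C(CO[N+](=O)[O-])Nc1ccc(C(=O)/C=C/c2ccco2)cc1` gives 48%.
Compound 3 `CC(O[N+](=O)[O-])C(=O)Nc1ccc(C(=O)/C=C/c2ccco2)cc1` gives 54%.

Compound 2 stands second highest of the three numbers, but its gaps to compound 1 and to compound 3 are both within the scatter, so no real ranking among the three follows from it. The measured steps are a number 6 percentage points higher from compound 1 to compound 2 (within the scatter), a number 6 percentage points higher from compound 2 to compound 3 (within the scatter) and a number 12 percentage points higher from compound 1 to compound 3 (beyond the scatter); only the last lies beyond the scatter, and it is modest.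

Compound 4 `C/C(=N/O)c1ccc(OCC(=O)Nc2ccc(C(=O)/C=C/c3ccco3)cc2)cc1` keeps the shared core and the amide of compound 2 and alters the chain end: a group of 10 heavy atoms (8 carbon, 1 nitrogen, 1 oxygen; one six-membered aromatic ring of carbon only) in place of a group of 3 heavy atoms (1 nitrogen, 2 oxygen; no ring), on an oxygen on a saturated carbon. Within the data shown here, no measured step exchanges the nitro group for anything, so none bears directly on this change; what the steps show is that growing the amide side chain has shifted this assay only by small amounts. A step not beyond the scatter is therefore expected, a number 4 percentage points higher from compound 2 to compound 4 (within the scatter). Compound 4 is estimated at 52%, with a range from 38% to 66%.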

Compound 4, a percentage reported as inhibition, in the whole organism at one dose (the size of the read-out at that dose, not a potency): 49%
Estimate against measurement, compound 4: 3 percentage points above, within the range that was stated.
By their numbers in this assay, from the lowest: compounds 1, 2, 4 and 3 (each within the scatter of the next, the first and the last beyond it).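

In this assay, the group of 10 heavy atoms, with its one six-membered aromatic ring of carbon only, in place of nitro on an oxygen on a saturated carbon gives a number 1 percentage points higher from compound 2 to compound 4 (within the scatter). The earlier compounds shown here all carried the nitro group or lacked the side chain altogether; this exchange shows that, at this position, a chain end without nitro still stands within the scatter of compound 2. Nothing at hand accounts for this result.

Open, from the compounds shown here alone, is whether a much smaller end on that oxygen, such as a methyl, or a different one, such as an amine or a carboxylic acid, would stay within the scatter as well. Also open, going by these compounds, is whether the methyl on the saturated chain carbon of compound 3 would have any bearing when combined with the new group.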